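Replacing the Octyl Chain of Compound 3 with Phenyl

The compounds below may be only part of what the source reports. "The series", "measured", "known", "first", "only" and "open" are said of these compounds alone.

Of the compounds shown here, three have been measured in an ADME assay on S9 fraction from liver (Rattus norvegicus) for metabolic stability, read by LC-MS, using NADPH, with a stated time of 30 min; on this read-out lower numbers stand for a less stable compound and higher numbers for a more stable compound. Compound 1 `CCCCCCCCc1ccc(OCC(=O)Cn2nnc(-c3ccccc3)n2)cc1` gives 33%, and compound 3 `CCCCCCCCc1ccc(OC(C)C(=O)Cn2nnc(-c3ccccc3)n2)cc1`, which carries a methyl in place of hydrogen on the saturated chain carbon bound to the carbonyl carbon and the oxygen on the aromatic ring, gives 40%. For compound 2 `CCCCCCCCc1ccc(OCC(=O)Cn2nnc(-c3ccc(C(=O)O)cc3)n2)cc1` the assay reports only a limit, < 5%, which is the limit (the limit of < 5% in this assay, at which 1 of the 3 values shown sits). Among the two numbers, compound 3 stands highest, with compound 1 nearest, though a number 7 percentage points higher from compound 1 to compound 3 (within the scatter). The carboxy group, by contrast, produced a number at least 28 percentage points lower from compound 1 to compound 2 (beyond the scatter).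

Compound 4 `CC(Oc1ccc(-c2ccccc2)cc1)C(=O)Cn1nnc(-c2ccccc2)n1` differs from compound 3 in one place: phenyl in place of octyl on an aromatic carbon. Neither measured step touches this part of the molecule; the methyl step from compound 1 to compound 3 sat within the scatter, and the carboxy step from compound 1 to compound 2 concerned a different ring. For the measured compounds named here, no measured step therefore bears directly on the exchange of the octyl chain, and the expectation for compound 4 rests on little. The estimate is that compound 4 will show a number 5 percentage points higher from compound 3 to compound 4 (within the scatter) in this assay, most likely no change beyond the scatter. Compound 4 is expected to give 45%, within a wide range from 15% to 80%.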

Compound 4, percent of the compound remaining: < 5%
Compound 4 was reported as a limit (the forecaster's own chance of this, stated with the estimate: 10%); at least 40 percentage points between middle value and limit.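

For the compounds shown here, the first change at this position, phenyl in place of octyl on an aromatic carbon para to a large group, produced in this assay a number at least 35 percentage points lower from compound 3 to compound 4 (beyond the scatter). The earlier compounds shown here showed a step of this kind only for the carboxy group on a different ring, so this result adds that the read-out also responds strongly to the group at this position, and that an exchange adding no hydrogen-bond donors, hydrogen-bond acceptors or net charge is enough to produce such a step. The result for compound 4 is a limit and not a number, so the size of the step has only a lower bound, and it is the second such result among these compounds: the limit of < 5% in this assay, at which 2 of the 4 values shown sit.

As far as these compounds go, what remains open is whether the step follows from the arrival of phenyl or from the departure of octyl, a question that a shorter chain such as butyl, or a saturated ring such as cyclohexyl, at the same position could help to settle. Also open, from the compounds shown here alone, is whether the same exchange would give a comparable step without the methyl that compound 3 carries on its saturated chain, and whether an amine on the new phenyl ring would change the read-out.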